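Swapping bromo for amino at the halogen position

The source may report more compounds than this note shows. Statements on the series, on what has been measured and on what is new or still open speak of the compounds shown alone.

Two compounds share one core and were read in an ADME assay on microsomes from liver (Homo sapiens) for metabolic stability, read by LC-MS, with a stated time of 15 min, tested at 1 uM, in the presence of a further agent that is not named here; on this read-out higher numbers stand for a more stable compound and lower numbers for a less stable compound. Compound 1 `CC(C)n1nc(-c2ccc3oc(N)nc3c2)c2c(F)nc(N)nc21` carries fluoro on the core and gives 83%. Compound 2 `CC(C)n1nc(-c2ccc3oc(N)nc3c2)c2c(Br)nc(N)nc21` carries bromo at the same place and gives 94%. Among the compounds with values here, the single step measured so far, a number 11 percentage points higher from compound 1 to compound 2 (beyond the scatter), is modest but beyond the scatter. Compound 2 therefore stands highest of the two numbers, and its nearest neighbour is compound 1.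

Compound 3 `CC(C)n1nc(-c2ccc3oc(N)nc3c2)c2c(N)nc(N)nc21` differs from compound 2 by one change: amino in place of bromo on an aromatic carbon. Within the data shown here, the only step that bears on it is the fluoro-to-bromo exchange between compound 1 and compound 2, and it concerned a different incoming group, so it gives no direct guide for amino. With one step of that size and no measurement of an amino group at this place, the expected step of a number 9 percentage points lower from compound 2 to compound 3 (within the scatter) is small, and may lie within the scatter. The estimate for compound 3 in this assay is 85%, expected within a range from 65% to 98%.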

Compound 3, percent of the compound remaining: > 95%
Compound 3 was reported as a limit; the forecaster's own chance of this, stated with the estimate: 0%; middle value at least 10 percentage points away from the limit.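

In this assay compound 3 gives > 95%, which is a limit of the assay and not an exact number: the limit of > 95% in this assay, at which 1 of the 3 values shown sits. Amino in place of bromo gives a number at least 1 percentage points higher from compound 2 to compound 3 (that floor lies within the scatter), so this step shows no clear gain, while amino in place of fluoro gives a number at least 12 percentage points higher from compound 1 to compound 3 (beyond the scatter), a difference that the scatter cannot account for. The earlier compounds shown here showed only one halogen exchanged for another, whereas this result shows that this place, next to the ring nitrogen, can also carry a non-halogen group, amino, with no loss that these numbers can detect.

As far as these compounds go, the limit hides the real number for compound 3, so it stays open whether amino truly ranks above bromo or whether the two simply match. Also open, from the compounds shown here alone, is how a larger group at this place, such as dimethylamino or methoxy, would fare in this assay, and whether the high stability would hold with a plain hydrogen on this aromatic carbon.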